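Swapping a chloro for a methoxy on the pyridine amide

The source may hold more compounds than are shown below. What is called first, only, known or untested is meant among the compounds shown, and "the series" means these compounds.

Compound 1 `COc1ncc(C(=O)NC2(C(=O)N[C@H](C)c3ccc(-n4nc(Cl)c5ccccc54)cc3F)CC2)s1` and compound 2 `C[C@@H](NC(=O)C1(NC(=O)c2cncc(Cl)c2)CC1)c1ccc(-n2nc(Cl)c3ccccc32)cc1F` share one core. In an in vivo ADME assay on the whole organism (strain Mongrel) for pharmacokinetics, with Canis familiaris (Canis lupus familiaris) as the target (on this read-out higher numbers stand for fast clearance and lower numbers for slow clearance), compound 1 gives 1.7 mL/min/kg, and compound 2 gives 3.1 mL/min/kg; the step of a 1.8-fold higher number from compound 1 to compound 2 (0.26 log units; within the scatter) shows the two cannot be told apart. Compound 3 `COc1cncc(C(=O)NC2(C(=O)N[C@H](C)c3ccc(-n4nc(Cl)c5ccccc54)cc3F)CC2)c1` differs from compound 2 by methoxy in place of chloro on an aromatic carbon. For the measured compounds named here, the only measured step, from a methoxy thiazole to a chloropyridine, was small, so the step of a 1.3-fold lower number from compound 2 to compound 3 (0.13 log units; within the scatter) is expected to stay within the scatter. Compound 3 is therefore estimated at 2.3 mL/min/kg, with a range from 1.2 mL/min/kg to 4.5 mL/min/kg.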

Compound 3, clearance: 5.5 mL/min/kg
Beside the measured number, compound 3's estimate is 2.4-fold (0.38 log units) below it; the measured number lies above the stated range.
By their numbers in this assay, from the lowest: compounds 1, 2 and 3 (each within the scatter of the next, the first and the last beyond it).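

In this assay, methoxy in place of chloro on the pyridine gives a 1.8-fold higher number from compound 2 to compound 3 (0.25 log units; within the scatter) and so cannot be told apart from repeat scatter at this position. Changing the ring instead, 5-methoxypyridin-3-yl in place of 2-methoxy-1,3-thiazol-5-yl, gives a 3.2-fold higher number from compound 1 to compound 3 (0.51 log units; beyond the scatter), the only step shown that is beyond the scatter, though modest. Nothing available explains either step. Going by these compounds, how an amine or a carboxylic acid at this pyridine position would change clearance remains open.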